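The source may report more compounds than this note shows. Statements on the series, on what has been measured and on what is new or still open speak of the compounds shown alone.

Compound 1 `O=C(CCl)Nc1ccc(I)cc1`: 5100 nM
Compound 2 `CC(C)(C)c1ccc(NC(=O)CCl)cc1`: 5400 nM
Compound 3 `C=CC(=O)Nc1ccc(C(C)(C)C)cc1`: not yet measured

In a functional assay on M21 cells (Homo sapiens) for antiproliferative activity, with a stated time of 48 h (on this read-out lower numbers stand for stronger inhibition and higher numbers for weaker inhibition), compound 2 stands level with compound 1. For the measured compounds named here, the only measured step is a 1.1-fold higher number from compound 1 to compound 2 (0.02 log units; within the scatter), which put tert-butyl in place of iodo on an aromatic carbon. Compound 3 keeps that tert-butyl and instead carries vinyl in place of chloromethyl on a carbonyl carbon. Going by the values given here, the measured step changed a different place, so it gives no size to carry over, and no measured pair tests this swap. The expectation therefore starts from compound 2 at 5400 nM and rests on the structural change alone, which makes it uncertain. The expected step is a 3.3-fold higher number from compound 2 to compound 3 (0.52 log units; beyond the scatter). For compound 3 the estimated value is 18000 nM, with an expected range from 6000 nM to 60000 nM.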

Compound 3, half-maximal inhibitory concentration: 22000 nM
Estimate against measurement, compound 3: 1.2-fold (0.09 log units) below; measured number inside the range.
By their numbers in this assay, from the lowest: compounds 1 and 2 (each within the scatter of the next); then compound 3.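

In this assay, the change on the carbonyl carbon from chloromethyl to vinyl gives a 4.1-fold higher number from compound 2 to compound 3 (0.61 log units; beyond the scatter) and so moves the number by a modest step beyond the scatter, whereas the earlier swap of iodo for tert-butyl on an aromatic carbon stayed within it. For the compounds shown here, this is the first sign that the read-out responds to the group on this carbonyl carbon, even though both groups count two heavy atoms and neither has a hydrogen-bond donor or acceptor. Nothing measured here gives a reason for the step.

On these data alone, it remains open whether vinyl in place of chloromethyl would give a similar step with iodo on the aromatic carbon. The compounds shown also leave open how a plain methyl or a longer chain such as chloroethyl would compare on this carbonyl carbon.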